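Nitro Substitution on a Phenyl Enol-Oxobutenoate Series

The source may hold more compounds than are shown below. What is called first, only, known or untested is meant among the compounds shown, and "the series" means these compounds.

The measured compounds:
compound 1, `COC(=O)C(=O)/C=C(\O)c1cccc(Cl)c1Cl`: 14%
compound 2, `O=C(O)C(=O)/C=C(\O)c1ccccc1`: 0%

In an assay for inhibition of kynurenine 3-monooxygenase (Rattus norvegicus), tested at 10 uM (on this read-out higher numbers stand for more inhibition at the one concentration tested (going by the name of the read-out) and lower numbers for less inhibition), compound 2 gives 0%, and in this assay compound 1 gives 14%. On these two numbers compound 2 stands lowest; its nearest neighbour is compound 1, whose value lies higher by a gap that goes beyond the usual scatter. Among the compounds with values here, compound 1 and compound 2 differ in more than one place, so no single step between them is counted, and nothing can be said about which of their differences carries the gap.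

Compound 3, `O=C(O)C(=O)/C=C(\O)c1ccccc1[N+](=O)[O-]`, has not been measured in this assay. It differs from compound 2 by nitro in place of hydrogen on an aromatic carbon. Within the data shown here, there is no measured pair in this set that isolates such a change, so the direction of the step can only be guessed from the fact that compound 2 sits at the bottom of the scale, where a fall is hardly possible. The step from compound 2 to compound 3 is therefore expected to be small and upward, likely within the scatter: a number 8 percentage points higher from compound 2 to compound 3 (within the scatter). Compound 3 is estimated to give 8%, with a range from -5% to 25%.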

Compound 3, a percentage reported as inhibition, at one concentration (the size of the read-out at that concentration, not a potency): 24%
Estimate against measurement, compound 3: 16 percentage points below, within the range that was stated.
By their numbers in this assay, from the lowest: compound 2; then compounds 1 and 3 (each within the scatter of the next).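

Within the data shown here, the change of nitro in place of hydrogen on an aromatic carbon, ortho to a group of 8 heavy atoms, gives the first single-place comparison in this set, and in this assay it is a number 24 percentage points higher from compound 2 to compound 3 (beyond the scatter). This shows that the position can respond to substitution, since a ring carrying only hydrogen there gave no measurable inhibition, while compound 3 gives 24%, a modest effect read at one concentration and not a potency. Nothing measured here bears on why the number rises, so the step stands as an observation with no explanation attached.

The compounds shown leave open whether this rise belongs to nitro specifically or would also come with another group on the same aromatic carbon, such as an amine or a nitrile. They also leave open how the step would carry over to the core of compound 1, which differs from compound 2 in more than one place, so that its ester and its chlorines cannot be separated from each other or set against the nitro step.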